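The source may hold more compounds than are shown below. What is called first, only, known or untested is meant among the compounds shown, and "the series" means these compounds.

Measured so far in a functional assay on RAW264.7 cells (Mus musculus) for inhibition, read by Griess assay, with a stated time of 20 h (on this read-out higher numbers stand for weaker inhibition and lower numbers for stronger inhibition), each value a limit of the assay and not a number:

Compound 1 `CCCNC(=O)c1cc(-n2cc(CCC(C)C)nn2)ccc1O`: > 20000 nM
Compound 2 `CCCNC(=O)c1cc(-n2cc(-c3cc(C(F)(F)F)cc(C(F)(F)F)c3)nn2)ccc1O`: > 20000 nM
Compound 3 `CCCCCCc1cn(-c2ccc(O)c(C(=O)N3CCCCC3)c2)nn1`: > 20000 nM

Going by the values given here, no measured compound in this small set gives an exact figure. The whole picture is the limit of > 20000 nM in this assay, at which 3 of the 3 values shown sit. On these data alone, compound 2 therefore stands at > 20000 nM, which is a limit, so its true position remains unknown.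

Compound 4 `O=C(c1cc(-n2cc(-c3cc(C(F)(F)F)cc(C(F)(F)F)c3)nn2)ccc1O)N1CCCCC1` differs from compound 2 in one place: piperidin-1-yl in place of propylamino on a carbonyl carbon. In words, piperidin-1-yl stands in place of propylamino on a carbonyl carbon.

Among the compounds with values here, no measured step shows what this change does in this assay. Compound 3 also has piperidin-1-yl on a carbonyl carbon, and its > 20000 nM is a limit too. No step beyond the usual scatter is therefore expected, in either direction, and another limit is the likeliest report. The expected step is a number no higher from compound 2 to compound 4 (the limit leaves the size open). For compound 4 the estimated value is 20000 nM, with an expected range from 7000 nM to 40000 nM.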

Compound 4, half-maximal inhibitory concentration: 12800 nM
Compound 4: the middle estimate sits 1.6-fold (0.19 log units) above what was measured, within the range that was stated.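

In this assay, compound 4 gives 12800 nM, the first exact figure in this set, showing that a compound carrying piperidin-1-yl on this carbonyl carbon can register within the measurable range. Replacing propylamino with piperidin-1-yl gives an at least 1.5-fold lower number from compound 2 to compound 4 (0.19 log units; that floor lies within the scatter), so these data do not establish a real gain from the change. Compound 3 also carries piperidin-1-yl, yet its > 20000 nM is a limit, and such limits remain the most common result: the limit of > 20000 nM in this assay, at which 3 of the 4 values shown sit.

On these data alone, the true size of the step remains open, as one end of it is only a limit. Also open, as far as these compounds go, is whether morpholine or a longer chain such as hexylamino on the same carbonyl carbon would give an exact figure, and how it would compare with piperidin-1-yl.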